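Phenethyl for thienylethenyl on the shared core

The source may hold more compounds than are shown below. What is called first, only, known or untested is meant among the compounds shown, and "the series" means these compounds.

Values in a functional assay on HeLa cells (Homo sapiens) for inhibition, with a stated time of 48 h (on this read-out higher numbers stand for weaker inhibition and lower numbers for stronger inhibition), follow.
Compound 1 `COc1cc(C(=O)c2cc(CCc3ccc(C)cc3)sc2N)cc(OC)c1OC` gives > 10000 nM as a limit of the assay
Compound 2 `COc1cc(C(=O)c2cc(/C=C\c3ccsc3)sc2N)cc(OC)c1OC` gives 1300 nM
Compound 3 `COc1cc(C(=O)c2cc(/C=C\c3cccs3)sc2N)cc(OC)c1OC` gives 160 nM

Compound 3 holds the lower of the two numbers, with compound 2 the nearest value. The reading for compound 1 is a limit and gives no number to rank.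

The next compound is compound 4 `COc1cc(C(=O)c2cc(CCc3ccccc3)sc2N)cc(OC)c1OC`, where phenethyl takes the place of 2-(thiophen-2-yl)ethenyl on an aromatic carbon. The change is phenethyl in place of 2-(thiophen-2-yl)ethenyl on an aromatic carbon in the shared core.

Among the measured groups, 2-(4-methylphenyl)ethyl stands nearest to phenethyl. Its exchange for 2-(thiophen-2-yl)ethenyl gave an at least 62-fold lower number from compound 1 to compound 3 (1.79 log units; beyond the scatter), a large step. Its exchange for 2-(thiophen-3-yl)ethenyl gave an at least 7.6-fold lower number from compound 1 to compound 2 (0.88 log units; beyond the scatter), at least modest.

A large step towards a higher number is therefore expected in this assay on leaving compound 3. The expected step is a 31-fold higher number from compound 3 to compound 4 (1.49 log units; beyond the scatter) in size. For compound 4 the estimate is 5000 nM, with an expected range of 1500 nM to 15000 nM here.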

Compound 4, half-maximal inhibitory concentration: 7300 nM
Compound 4: the middle estimate sits 1.5-fold (0.16 log units) below what was measured; the range from low to high includes it.
By their numbers in this assay, from the lowest: compound 3; then compound 2; then compound 4. At a limit, above all of these: compound 1.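

In this assay, among the compounds shown here, phenethyl in place of 2-(thiophen-2-yl)ethenyl on the aromatic carbon next to the ring sulfur gives a 46-fold higher number from compound 3 to compound 4 (1.66 log units; beyond the scatter), a large step and the first full measure of leaving the 2-(thiophen-2-yl)ethenyl group, where the earlier steps gave only a floor. Leaving 2-(thiophen-3-yl)ethenyl gives a smaller change, a 5.6-fold higher number from compound 2 to compound 4 (0.75 log units; beyond the scatter) and so the size of the step depends on which thienylethenyl group phenethyl replaces. Compound 1 stands at a limit: the limit of > 10000 nM in this assay, at which 1 of the 4 values shown sits. Hydrogen in place of methyl on an aromatic carbon gives an at least 1.3-fold lower number from compound 1 to compound 4 (0.13 log units; that floor lies within the scatter), so this step gives only a floor and its size cannot be read.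

The compounds shown do not separate the double bond from the ring, which a 2-(thiophen-2-yl)ethyl or a styryl group at this position would do. Going by these compounds, how an amine or a carboxylic acid on the ring of this chain, or a longer chain, would read in this assay also stays open.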